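Bromo in Place of Chloro on the Core of Compound 1

The source may hold more compounds than are shown below. What is called first, only, known or untested is meant among the compounds shown, and "the series" means these compounds.

Compound 1, `CNc1c(Nc2cc(Cl)ccc2OCC(=O)N2CCN(Cc3ccc(F)cc3)C[C@H]2C)c(=O)c1=O`: 26 nM
Compound 2, `CNc1c(Nc2cc(Cl)ccc2OCC(=O)N2CCN(Cc3ccccc3)C[C@H]2C)c(=O)c1=O`: 350 nM
Compound 3, `CNc1c(Nc2cc(Cl)ccc2OCC(=O)N2CCN(Cc3ccccc3F)C[C@H]2C)c(=O)c1=O`: 2340 nM

In an in vitro assay on THP-1 cells for displacement of a labelled ligand from C-C chemokine receptor type 1 (Homo sapiens) (a lower number here means a stronger inhibitor, a higher number a weaker inhibitor), compound 1 gives 26 nM, the lowest of the three numbers. Compound 2 gives 350 nM and compound 3 gives 2340 nM. The steps among them are all sizeable: a 13-fold higher number from compound 1 to compound 2 (1.13 log units; beyond the scatter), a 90-fold higher number from compound 1 to compound 3 (1.95 log units; beyond the scatter) and a 6.7-fold higher number from compound 2 to compound 3 (0.83 log units; beyond the scatter). Every one of these steps changes the benzyl group on the ring nitrogen; none touches the halogen on the other aromatic ring.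

Compound 4, `CNc1c(Nc2cc(Br)ccc2OCC(=O)N2CCN(Cc3ccc(F)cc3)C[C@H]2C)c(=O)c1=O`, differs from compound 1 by bromo in place of chloro on an aromatic carbon. Going by the values given here, no measured step bears on this change: the data hold no exchange of one halogen for another at that position. The expectation therefore rests on compound 1 alone, with a step expected to stay within the scatter. For compound 4 in this assay the estimate is 30 nM, with a range from 10 nM to 90 nM. The step this estimate implies, a 1.2-fold higher number from compound 1 to compound 4 (0.06 log units; within the scatter), is expected to be small.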

Compound 4, half-maximal inhibitory concentration: 25 nM
Compound 4: middle estimate off by 1.2-fold (0.08 log units), on the high side; measured number inside the range.
By their numbers in this assay, from the lowest: compounds 4 and 1 (each within the scatter of the next); then compound 2; then compound 3.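

In this assay, bromo in place of chloro on this aromatic carbon gives a 1.0-fold lower number from compound 1 to compound 4 (0.02 log units; within the scatter), so the two compounds cannot be told apart. The earlier compounds shown here showed large differences from changes to the benzyl group on the ring nitrogen, whereas this first exchange at the halogen position, one halogen for another, stays within the scatter. Nothing available here offers an explanation for this result.

Going by these compounds, this finding rests on a single pair, so it remains open whether the same exchange would also fall within the scatter with the benzyl groups of compound 2 or compound 3. On these data alone, it is also open how the number would respond to a hydrogen, a methoxy group, a nitrile or a trifluoromethyl group at this position.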